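Five-membered heteroaryl in place of pyridyl: compound 4

The compounds below may be only part of what the source reports. "The series", "measured", "known", "first", "only" and "open" are said of these compounds alone.

Measured so far:
compound 1 `Cc1cc(C)c(NC(=O)N(Cc2ccc(-c3nnc(C)o3)cc2)C2CCCCCC2)c(C)c1` — > 0.32 mg/kg
compound 2 `Cc1cc(C)c(NC(=O)N(Cc2ccc(-c3ccsc3)cc2)C2CCCCCC2)c(C)c1` — 0.51 mg/kg
compound 3 `Cc1cc(C)c(NC(=O)N(Cc2ccc(-c3ccccn3)cc2)C2CCCCCC2)c(C)c1` — > 1 mg/kg

In a functional assay on a cell-free system (plasma) with sterol O-acyltransferase, Soat (Rattus norvegicus) as the target (a higher number here means that more compound is needed for the effect, a lower number that less compound is needed), compound 3 gives > 1 mg/kg, a limit of the assay and not a number (the limit of > 1 mg/kg in this assay, at which 1 of the 3 values shown sits). Compound 1 also stands at a limit of the assay, > 0.32 mg/kg (the limit of > 0.32 mg/kg in this assay, at which 1 of the 3 values shown sits). Compound 2 gives 0.51 mg/kg. The step of an at least 1.9-fold higher number from compound 2 to compound 3 (0.29 log units; that floor lies within the scatter) has a floor inside the scatter; a step that the limit leaves unreadable from compound 1 to compound 2 and a step that the two limits leave unreadable from compound 1 to compound 3 cannot be read. Compound 4 `Cc1cc(C)c(NC(=O)N(Cc2ccc(-n3cccn3)cc2)C2CCCCCC2)c(C)c1` differs from compound 3 by 1H-pyrazol-1-yl in place of pyridin-2-yl on an aromatic carbon. Only an at least 1.9-fold higher number from compound 2 to compound 3 (0.29 log units; that floor lies within the scatter) bears on a ring change of this kind, and it allows no more than a small expectation in either direction. Compound 4 is therefore expected in this assay at 1 mg/kg, with a range of 0.4 mg/kg to 3 mg/kg. The expected step of a number no higher from compound 3 to compound 4 (the limit leaves the size open) stays unreadable against a limit.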

Compound 4, dose for half-maximal effect: > 1 mg/kg
Compound 4: no number, only a limit; the forecaster's own chance of this, stated with the estimate: 40%; the middle value sits exactly at the limit.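

In this assay compound 4 gives > 1 mg/kg, a limit and not a number, so a five-membered ring at this place reads no differently from the six-membered pyridin-2-yl: the limit of > 1 mg/kg in this assay, at which 2 of the 4 values shown sit.

The change from thiophen-3-yl to 1H-pyrazol-1-yl gives an at least 1.9-fold higher number from compound 2 to compound 4 (0.29 log units; that floor lies within the scatter). The steps to compound 4 from compound 1 and compound 3 cannot be read.

As far as these compounds go, whether 1H-pyrazol-1-yl and pyridin-2-yl differ at all remains open. So does how a carboxylic acid or an amine would read at this place on the shared core.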